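Taking the fluoro off the lowest of three compounds

The compounds below may be only part of what the source reports. "The series", "measured", "known", "first", "only" and "open" are said of these compounds alone.

In a functional assay on HL-60 cells (Homo sapiens) for inhibition, read by MTT assay, with a stated time of 72 h (on this read-out lower numbers stand for stronger inhibition and higher numbers for weaker inhibition), compound 1 `CCOc1cccc(N2CCN(C(=O)c3oc(C)nc3-c3ccccc3)CC2)c1` gives 151 nM and compound 2 `Cc1nc(-c2ccccc2)c(C(=O)N2CCN(c3c(C)cccc3C)CC2)o1` gives 146 nM, with a 1.0-fold lower number from compound 1 to compound 2 (0.01 log units; within the scatter). Compound 3 `Cc1nc(-c2ccccc2)c(C(=O)N2CCN(c3cccc(F)c3)CC2)o1` has the lowest number of the three, at 45 nM. Two measured steps lead to it: a 3.4-fold lower number from compound 1 to compound 3 (0.53 log units; beyond the scatter), with fluoro in place of ethoxy, and a 3.2-fold lower number from compound 2 to compound 3 (0.51 log units; beyond the scatter). Compound 4 `Cc1nc(-c2ccccc2)c(C(=O)N2CCN(c3ccccc3)CC2)o1` has hydrogen in place of fluoro on an aromatic carbon. Neither measured step removes the fluoro and leaves nothing in its place, so both bear on this change only loosely. They suggest a small move towards a higher number, no larger than those modest steps. The expected step is a 1.8-fold higher number from compound 3 to compound 4 (0.25 log units; within the scatter). For compound 4 the estimated value is 80 nM, within a range of 35 nM to 190 nM.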

Compound 4, half-maximal inhibitory concentration: 39.1 nM
Compound 4: the middle estimate sits 2.0-fold (0.31 log units) above what was measured; measured number inside the range.
By their numbers in this assay, from the lowest: compounds 4 and 3 (each within the scatter of the next); then compounds 2 and 1 (each within the scatter of the next).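

Swapping fluoro for hydrogen on this aromatic carbon gives a 1.2-fold lower number from compound 3 to compound 4 (0.06 log units; within the scatter), so here the fluoro adds nothing that this test can detect. Plain phenyl also keeps the advantage over both substituted rings, with a 3.7-fold lower number from compound 2 to compound 4 (0.57 log units; beyond the scatter) and a 3.9-fold lower number from compound 1 to compound 4 (0.59 log units; beyond the scatter), which means neither the ethoxy nor the two methyl groups are needed for the lower numbers. Nothing available explains why these changes behave this way. As far as these compounds go, whether a chloro group, an amine or a carboxylic acid at this place would stay level with hydrogen and fluoro remains open.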